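This account rests on a few compounds, and the source may have more. Where it says the series, first, only, none or still open, it means among the compounds named here.

Measured in a functional assay on SH-SY5Y cells (Homo sapiens); a lower number here means that less compound is needed, a higher number that more compound is needed for the effect:

- compound 1 `O=P(O)(O)OC1[C@H](O)CC(OP(=O)(O)O)[C@H](OP(=O)(O)O)[C@@H]1O`: 156 nM
- compound 2 `O=P(O)(O)OC1CCC(OP(=O)(O)O)[C@H](OP(=O)(O)O)[C@@H]1O`: 186 nM

Among the measured compounds shown here, only these two compounds have numbers so far, and they lie within the scatter of each other. Compound 2, at 186 nM, therefore cannot be separated from compound 1.

The next compound is compound 3 `O=P(O)(O)OC1CCC(OP(=O)(O)O)[C@H](OP(=O)(O)O)C1`. It differs from compound 2 by one change: hydrogen in place of hydroxy on a saturated ring carbon. The replaced hydroxy is the one on the ring carbon next to two ring atoms that each bear a group of 5 heavy atoms.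

One measured step is of the same kind, a 1.2-fold higher number from compound 1 to compound 2 (0.08 log units; within the scatter). It removed a different hydroxy, so it is only a loose guide to this one, and a single small step does not show that every such replacement is harmless. For the measured compounds named here, the new change also leaves compound 3 without the remaining ring hydroxy, which no measured compound lacks. A clear move towards a higher number in this assay is therefore expected, though its size is uncertain. The expected change is an 8.1-fold higher number from compound 2 to compound 3 (0.91 log units; beyond the scatter). For compound 3 the estimated value is 1500 nM, with an expected range from 250 nM to 10000 nM.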

Compound 3, half-maximal effective concentration: > 10000 nM
Compound 3 gave a limit, no number (the forecaster's own chance of this, stated with the estimate: 5%); middle value at least 6.6-fold (0.82 log units) away from the limit.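

In this assay, this replacement of hydroxy by hydrogen gives an at least 53-fold higher number from compound 2 to compound 3 (1.73 log units; beyond the scatter), whereas the same kind of replacement at a different hydroxy gave a 1.2-fold higher number from compound 1 to compound 2 (0.08 log units; within the scatter). The earlier step therefore did not carry over: swapping a ring hydroxy for hydrogen can pass without a clear effect at one place, yet cost heavily on the ring carbon next to two ring atoms that each bear a group of 5 heavy atoms, where compound 2 holds its last ring hydroxy. The value of compound 3, > 10000 nM, is a limit of the assay and not a number: the limit of > 10000 nM in this assay, at which 1 of the 3 values shown sits.

Only hydrogen has taken the place of this hydroxy in the compounds shown, so it remains open whether another group there, such as a methoxy, a fluorine or an amine, would keep the effect. On these data alone, it is also open whether the large step belongs to this particular hydroxy alone or to compound 3 having no ring hydroxy left at all.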